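Cyano to Trifluoromethyl on the Pendant Aryl Ring

This account rests on a few compounds, and the source may have more. Where it says the series, first, only, none or still open, it means among the compounds named here.

Compound 1 `CN(C)CCCCOC(=O)Nc1ccc(Cn2nc(-c3ccc(C#N)cc3)c3ccccc3c2=O)cc1` and compound 3 `CN(C)CCCCOC(=O)Nc1ccc(Cn2nc(-c3ccccc3C#N)c3ccccc3c2=O)cc1` share one core; their difference is 2-cyanophenyl in place of 4-cyanophenyl on an aromatic carbon. In an ADME assay on Huh-7 cells (Homo sapiens) for cytotoxicity, read by MTT assay, with a stated time of 48 h (on this read-out higher numbers stand for lower toxicity in this test and lower numbers for higher toxicity in this test), compound 1 gives 37000 nM, and compound 3 gives 90700 nM, so a 2.5-fold higher number from compound 1 to compound 3 (0.39 log units; beyond the scatter). Compound 2 `CN(C)CCCCOC(=O)Nc1ccc(Cn2nc(-c3ccc(C(F)(F)F)cc3)c3ccccc3c2=O)cc1` differs from compound 1 by trifluoromethyl in place of cyano on an aromatic carbon, and in this assay compound 2 gives 3360 nM, giving an 11-fold lower number from compound 1 to compound 2 (1.04 log units; beyond the scatter) and a 27-fold higher number from compound 2 to compound 3 (1.43 log units; beyond the scatter). Compound 4 `CN(C)CCCCOC(=O)Nc1ccc(Cn2nc(-c3ccccc3C(F)(F)F)c3ccccc3c2=O)cc1` carries the same kind of change on the core of compound 3, namely (trifluoromethyl in place of cyano on an aromatic carbon); here the group sits ortho to a large group, where in compound 2 it sits para to a large group. Because an 11-fold lower number from compound 1 to compound 2 (1.04 log units; beyond the scatter) was observed, a step of a 10-fold lower number from compound 3 to compound 4 (1.00 log units; beyond the scatter) is expected for compound 4. Compound 4 is therefore estimated at 9000 nM, with a range from 3000 nM to 30000 nM.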

Compound 4, half-maximal cytotoxic concentration: 35700 nM
Compound 4: middle estimate off by 4.0-fold (0.60 log units), on the low side, outside the stated range (above it).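

Trifluoromethyl in place of cyano gives a 2.5-fold lower number from compound 3 to compound 4 (0.40 log units; beyond the scatter) in this assay, the same direction as on the core of compound 1, but the two steps differ in size: the same change on two cores in this assay, an 11-fold lower number (1.04 log units; beyond the scatter) from compound 1 to compound 2 and a 2.5-fold lower number (0.40 log units; beyond the scatter) from compound 3 to compound 4, 4.3-fold (0.64 log units) apart, beyond the scatter of two such steps. The direction thus carried over in this one pair of cores while the size did not; an 11-fold higher number from compound 2 to compound 4 (1.03 log units; beyond the scatter) sets the two trifluoromethyl compounds far apart, whereas a 1.0-fold lower number from compound 1 to compound 4 (0.02 log units; within the scatter) lies within the scatter. Two pairs cannot show why the size differs, nor whether the direction would hold on any other core.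

The compounds shown leave open how a chlorine or a methoxy group would compare with cyano and trifluoromethyl on the pendant aryl ring. They also leave open whether the step would persist with a shorter chain or with a morpholine in place of the dimethylamino group.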